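Branched chain at the amine-bearing carbon: outlook for compound 3

A few compounds are considered here, and "the series" means these few. Any claim that something is new, unique, unknown or untested is made for them only; others in the source may bear on it.

Measured so far:
compound 1: `CC(C)C[C@H](N)CN(C(=O)[C@@H]1C[C@H]1c1ccccc1)c1ccc(-c2ccccc2)cc1` — 880 nM
compound 2: `CC[C@@H](C)[C@H](N)CN(C(=O)[C@@H]1C[C@H]1c1ccccc1)c1ccc(-c2ccccc2)cc1` — 1.4 nM

In a functional assay for agonist activity at G protein-coupled receptor 88 (Homo sapiens), read by HTRF and cAMP accumulation (a higher number here means that more compound is needed for the effect, a lower number that less compound is needed), compound 1 gives 880 nM, the highest of the two numbers; compound 2 gives 1.4 nM. Among the compounds with values here, the only measured step is a 630-fold lower number from compound 1 to compound 2 (2.80 log units; beyond the scatter), a single change from isobutyl to sec-butyl on a saturated chain carbon bound to an amine nitrogen and a saturated chain carbon.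

Compound 3 is `N[C@H](CN(C(=O)[C@@H]1C[C@H]1c1ccccc1)c1ccc(-c2ccccc2)cc1)C1CCCCC1`. It differs from compound 1 in the same place: cyclohexyl in place of isobutyl on a saturated chain carbon bound to an amine nitrogen and a saturated chain carbon.

The step of a 630-fold lower number from compound 1 to compound 2 (2.80 log units; beyond the scatter) is the only one that bears on this change, and it is large. Both it and the move to compound 3 replace isobutyl at the same saturated chain carbon, so a lower number by a large margin is expected for compound 3 as well, though the sec-butyl result is one point only and cyclohexyl is a different group, so the size is uncertain. Compound 3 is therefore estimated at 10 nM, within 1.5 nM to 80 nM. This estimate corresponds to an expected step of an 88-fold lower number from compound 1 to compound 3 (1.94 log units; beyond the scatter).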

Compound 3, half-maximal effective concentration: 0.66 nM
Compound 3: the middle estimate sits 15-fold (1.18 log units) above what was measured, and the stated range ends above it.
By their numbers in this assay, from the lowest: compound 3; then compound 2; then compound 1.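

Cyclohexyl is a second replacement for isobutyl on this saturated chain carbon bound to an amine nitrogen and a saturated chain carbon, and in this assay it gives a 1300-fold lower number from compound 1 to compound 3 (3.12 log units; beyond the scatter) as its step, so the large fall in the number is not confined to sec-butyl. Among the three compounds shown, both replacements of isobutyl lead to a far lower number, and neither goes against this, even though cyclohexyl brings one six-membered non-aromatic ring of carbon only where sec-butyl has no ring. The two replacements themselves lie much closer together, with a 2.1-fold lower number from compound 2 to compound 3 (0.33 log units; beyond the scatter) as a modest step that is printed as beyond the scatter, and the data offer no explanation for either the large steps or the modest one.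

The compounds shown leave open whether a smaller ring such as cyclopentyl, or an aromatic phenyl, would keep the number in this assay as low at this carbon. They also leave open whether a hydroxyl or an amine on the cyclohexyl ring would be tolerated.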